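Imidazolyl for pyrrolidinyl on the butynyl chain: expected inactivity

The compounds below may be only part of what the source reports. "The series", "measured", "known", "first", "only" and "open" are said of these compounds alone.

The series is read in a functional assay on the whole organism for agonist activity, with Mus musculus as the target; on this read-out lower numbers stand for an effect already at smaller amounts and higher numbers for an effect only at larger amounts of compound. Compound 1 `CCOC(=O)N(C)CC#CCN1CCCC1` carries a pyrrolidin-1-yl group on the butynyl chain; compound 2 `CCOC(=O)N(C)CC#CCn1ccnc1` carries 1H-imidazol-1-yl in its place, a difference counted as 1H-imidazol-1-yl in place of pyrrolidin-1-yl on a saturated chain carbon bound to a triple-bonded carbon. In this assay compound 1 gives only a limit, > 100 mg/kg. In this assay compound 2 likewise gives only a limit, > 100 mg/kg. The step that the two limits leave unreadable from compound 1 to compound 2 therefore cannot be sized, because both of its ends sit at the limit of > 100 mg/kg in this assay, at which 2 of the 3 values shown sit.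

Compound 3 `CC(C#CCN1CCCC1)N1CCN(C)C1=O` has a different core; the difference between the two cores is not broken down here. In this assay compound 3 gives only a limit, > 30 mg/kg, which is the limit of > 30 mg/kg in this assay, at which 1 of the 3 values shown sits. Compound 4 `CC(C#CCn1ccnc1)N1CCN(C)C1=O` is not yet measured and differs from compound 3 by 1H-imidazol-1-yl in place of pyrrolidin-1-yl on a saturated chain carbon bound to a triple-bonded carbon. The place of the change is worded identically for both pairs, so this is the same change as that from compound 1 to compound 2.

Among the compounds with values here, since every value shown is a limit and the one measured instance of this change is unreadable, the expected step that the limit leaves unreadable from compound 3 to compound 4 is set near zero with wide uncertainty. Compound 4 is accordingly expected to give 60 mg/kg in this assay, with a range from 20 mg/kg to 300 mg/kg and a high chance that only a limit is reported again.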

Compound 4, dose for half-maximal effect: > 100 mg/kg
Compound 4 ended at the assay's limit (the forecaster's own chance of this, stated with the estimate: 85%); at least 1.6-fold (0.22 log units) between middle value and limit.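

In this assay, compound 3 and compound 4 both give only limits of the assay, so no step can be read between them, and the same holds for compound 1 and compound 2. The compounds shown leave open whether 1H-imidazol-1-yl in place of pyrrolidin-1-yl changes the dose for half-maximal effect at all, and whether any compound on either core reaches a numerical value in this assay.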